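Adding a Nitro Group to Compound 2

The source may hold more compounds than are shown below. What is called first, only, known or untested is meant among the compounds shown, and "the series" means these compounds.

Compound 1 `Cc1ccc(NS(=O)(=O)c2ccccc2)c([N+](=O)[O-])c1`: 60300 nM
Compound 2 `O=S(=O)(Nc1ccccc1)c1ccccc1`: > 100000 nM

Both compounds were tested in a functional assay on PC-3 cells (Homo sapiens) for cytotoxicity, read by MTT assay, with a stated time of 5 days; a higher number here means a weaker inhibitor of growth, a lower number a stronger inhibitor of growth. Compound 2 gives > 100000 nM, which is a limit of the assay and not a number. Compound 1, which also carries a nitro group, gives 60300 nM, a true number.

Compound 3 `O=[N+]([O-])c1ccccc1NS(=O)(=O)c1ccccc1` departs from compound 2 in one place: nitro in place of hydrogen on an aromatic carbon. This puts nitro in place of hydrogen on an aromatic carbon, ortho to a large group. Going by the values given here, no measured step shows what this change does in this assay, so the only guide is compound 1 at 60300 nM. A modest gain in growth inhibition is expected, and the reading may still remain at the limit. The expected change is an at least 1.4-fold lower number from compound 2 to compound 3 (0.15 log units; that floor lies within the scatter). For compound 3 the estimated value is 70000 nM, with an expected range of 30000 nM to 100000 nM.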

Compound 3, concentration for 50% growth inhibition: 22900 nM
The estimate for compound 3 lay 3.1-fold (0.49 log units) above the measured number; the whole stated range lies above it.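

In this assay, nitro in place of hydrogen on an aromatic carbon, ortho to a large group, can now be read as a single change, and it gives an at least 4.3-fold lower number from compound 2 to compound 3 (0.64 log units; beyond the scatter). Compound 2 has a limit of the assay here and not a number, so this step is only a floor: the limit of > 100000 nM in this assay, at which 1 of the 3 values shown sits. With nitro kept, hydrogen in place of methyl on an aromatic carbon gives a 2.6-fold lower number from compound 1 to compound 3 (0.42 log units; beyond the scatter), so in this pair the methyl group does not add to growth inhibition but goes with a weaker result.

Going by these compounds, whether another group on the same aromatic carbon, such as an amine or a nitrile, would give a similar step stays open. The compounds shown also carry nitro only ortho to a large group, so its effect elsewhere on that ring is unknown.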